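The compounds below may be only part of what the source reports. "The series", "measured", "known", "first", "only" and "open" are said of these compounds alone.

Measured to date in an assay on isolated protein for inhibition of proto-oncogene tyrosine-protein kinase receptor Ret (Homo sapiens), read by mobility shift assay, with a stated time of 1 h, tested at 10 uM; on this read-out lower numbers stand for less inhibition and higher numbers for more inhibition at the one concentration tested (going by the name of the read-out):
compound 1, `CN(C)CCCn1cnnc1-c1cc(Oc2ccc(NC(=O)Nc3ccc(Cl)c(C(F)(F)F)c3)cc2F)ccn1`: 79.3%
compound 2, `CN(C)CCCn1cnnc1-c1cc(Oc2ccc(NC(=O)Nc3cccc(C(F)(F)F)c3)cc2F)ccn1`: 85.6%
compound 3, `CN(C)CCCn1cnnc1-c1cc(Oc2ccc(NC(=O)Nc3ccccc3C(F)(F)F)cc2F)ccn1`: "not determined" (no result reported)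

Within the data shown here, the one step between measured compounds in this assay, a number 6.3 percentage points higher from compound 1 to compound 2 (within the scatter), is a hydrogen in place of chloro on an aromatic carbon and falls within the scatter. Compound 3 has no result reported in this assay, so it cannot be placed among compounds 1 and 2; it shares their core and their aryl urea with a trifluoromethyl group, differing only in where that group stands.

Compound 4, `CN(C)CCCn1cnnc1-c1cc(Oc2ccc(NC(=O)Nc3ccc(F)c(F)c3)cc2F)ccn1`, differs from compound 3 by 3,4-difluorophenyl in place of 2-(trifluoromethyl)phenyl on an amide-type nitrogen. Among the measured compounds shown here, no measured step touches this kind of exchange: the step from compound 1 to compound 2 alters a substituent on the same ring but keeps the trifluoromethyl group, and compound 3 itself is unmeasured. For the measured compounds named here, the only anchors are compounds 1 and 2, both of which inhibit strongly at the tested concentration. Compound 4 is therefore expected, with a wide range, to give 70% in this assay, between 40% and 92%.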

Compound 4, a percentage reported as inhibition, at one concentration (the size of the read-out at that concentration, not a potency): 30.9%
The estimate for compound 4 lay 39.1 percentage points above the measured number, and the stated range ends above it.
By their numbers in this assay, from the lowest: compound 4; then compounds 1 and 2 (each within the scatter of the next).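

In this assay, the aryl group on the amide-type nitrogen now proves able to move the read-out well beyond the scatter: 3,4-difluorophenyl in place of 3-(trifluoromethyl)phenyl gives a number 54.7 percentage points lower from compound 2 to compound 4 (beyond the scatter), and 3,4-difluorophenyl in place of 4-chloro-3-(trifluoromethyl)phenyl gives a number 48.4 percentage points lower from compound 1 to compound 4 (beyond the scatter). Among the three compounds with numbers, the two carrying the trifluoromethyl group both read high, while compound 4, without it, reads low. Nothing at hand explains this drop.

Still open, on these data alone, is whether the loss follows the departure of the trifluoromethyl group or the arrival of the fluoro groups, as the exchange changes both at once. As far as these compounds go, how a nitrile or a methoxy group would read in place of the trifluoromethyl group also remains unknown.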